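Compound 3 at the limit and its alkene relative

This account rests on a few compounds, and the source may have more. Where it says the series, first, only, none or still open, it means among the compounds named here.

Values in a functional assay on K562 cells (Homo sapiens) for antiproliferative activity, read by MTT assay, with a stated time of 48 h (a lower number here means a stronger inhibitor, a higher number a weaker inhibitor), stand as follows.
- Compound 1 `COc1cc(CNC(=O)CCCCCCC(C)C)ccc1OCCCCOc1ccc(C(N)=S)cc1` gives > 50000 nM as a limit
- Compound 2 `COc1cc(CNC(=O)CCCCCCC(C)C)ccc1OC(=O)CCC(=O)Oc1ccc(-c2cc(=S)ss2)cc1` gives 5930 nM as a number
- Compound 3 `COc1cc(CNC(=O)CCCCCCC(C)C)ccc1OC(=O)c1ccc(C(N)=S)cc1` gives > 50000 nM as a limit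

Compound 3 stands at the limit of > 50000 nM in this assay, at which 2 of the 3 values shown sit, and so has a limit and no number. Of the three compounds, only compound 2 has a measured number.

Compound 4 `COc1cc(CNC(=O)CCCC/C=C/C(C)C)ccc1OC(=O)c1ccc(C(N)=S)cc1` keeps the rest of compound 3 and carries 3-methylbut-1-en-1-yl in place of isopentyl on a saturated chain carbon, four bonds along the chain from a carbonyl carbon. For the measured compounds named here, no measured pair shows what this change does. No step beyond the scatter is therefore expected in this assay and the activity is expected to stay weak. This expectation rests on compound 3 with its limit of > 50000 nM as the reading. The estimated change is a number no higher from compound 3 to compound 4 (the limit leaves the size open) and no clear direction is expected. The expected value for compound 4 is 50000 nM with an estimated range from 20000 nM to 120000 nM and the assay may well report only a limit.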

Compound 4, half-maximal inhibitory concentration: > 50000 nM
Compound 4: no number, only a limit (the forecaster's own chance of this, stated with the estimate: 70%); the middle value lies on the limit itself.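

Compound 3 and compound 4 each give only a limit in this assay, so no step between them can be read: the limit of > 50000 nM in this assay, at which 3 of the 4 values shown sit.

The compounds shown leave open whether 3-methylbut-1-en-1-yl in place of isopentyl changes the activity at all, and in which direction.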